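This account rests on a few compounds, and the source may have more. Where it says the series, first, only, none or still open, it means among the compounds named here.

Among the measured compounds shown here, in an ADME assay for permeability, using PAMPA, at pH 7.4 (on this read-out lower numbers stand for lower permeability and higher numbers for higher permeability), compound 1 `O=C(Nc1cccc(-c2nc3ccccc3s2)c1)c1cc([N+](=O)[O-])ccc1Cl` gives 12 10^-6 cm/s and compound 2 `Cc1ccc(-c2nc3ccccc3s2)cc1NC(=O)c1cc([N+](=O)[O-])ccc1Cl` gives 41 10^-6 cm/s as the higher of the two numbers so far. Compound 3 `O=C(Nc1cc(-c2nc3ccccc3s2)ccc1F)c1cc([N+](=O)[O-])ccc1Cl` is still unmeasured and differs from compound 2 by fluoro in place of methyl on an aromatic carbon in a change of fluoro in place of methyl on an aromatic carbon. For the measured compounds named here, the one measured step bearing on this is a 3.4-fold higher number from compound 1 to compound 2 (0.53 log units; beyond the scatter) for methyl in place of hydrogen on an aromatic carbon, a modest step beyond the scatter. Going by the values given here, compound 3 gives up that methyl but takes fluoro rather than hydrogen, and no measured compound shows what fluoro does here. A lower number in this assay is therefore expected, though no step beyond the scatter: the estimated move is a 1.7-fold lower number from compound 2 to compound 3 (0.23 log units; within the scatter) and no larger one is assumed. Compound 3 is estimated at 24 10^-6 cm/s within an expected range from 10 10^-6 cm/s to 55 10^-6 cm/s on this read-out.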

Compound 3, apparent permeability: 191 10^-6 cm/s
The estimate for compound 3 lay 8.0-fold (0.90 log units) below the measured number; the measured number lies above the stated range.
By their numbers in this assay, from the lowest: compound 1; then compound 2; then compound 3.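

Among the compounds shown here, at this aromatic carbon, ortho to a large group and para to a 1,3-benzothiazol-2-yl group, the earlier compounds showed only that methyl raised the number over hydrogen in this assay. Fluoro goes considerably further, with a 16-fold higher number from compound 1 to compound 3 (1.20 log units; beyond the scatter) for fluoro in place of hydrogen and still a 4.7-fold higher number from compound 2 to compound 3 (0.67 log units; beyond the scatter) when it replaces methyl, so the position orders hydrogen, methyl and fluoro from lowest to highest, each step beyond the scatter. Nothing available explains why fluoro gives the highest number of the three.

As far as these compounds go, whether chloro, methoxy or an amine on this carbon would fall within that order remains open. From the compounds shown here alone, it is also open whether fluoro would give a step of similar size on another carbon of the same ring.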